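Dropping the Benzylic Methyl in a Hydroxamic Acid Series

The source may report more compounds than this note shows. Statements on the series, on what has been measured and on what is new or still open speak of the compounds shown alone.

Compound 2 `Cc1ccc(CNC(=O)CCN(Cc2ccc(C(=O)NO)cc2)C(=O)c2ccc(N(C)C)cc2)cc1` was tested in a functional assay on G55T2 cells (Homo sapiens) for antiproliferative activity, read by WST assay, with a stated time of 72 h (a higher number here means a weaker inhibitor, a lower number a stronger inhibitor), where compound 2 gives 430 nM. Within the data shown here, of the three numbers measured so far, this is the lowest. Compound 3 `Cc1ccc(NC(=O)CCN(Cc2ccc(C(=O)NO)cc2)C(=O)c2ccccc2)cc1` gives 540 nM, a number that lies within the scatter of compound 2, so the two cannot be told apart. Compound 1 `Cc1cc(C)cc(C(=O)N(CCC(=O)NCc2ccccc2)Cc2ccc(C(=O)NO)cc2)c1` gives 4250 nM, which stands beyond the scatter above compound 2.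

Compound 4 `CN(C)c1ccc(C(=O)N(CCC(=O)NCc2ccccc2)Cc2ccc(C(=O)NO)cc2)cc1` has not yet been measured in this assay. It differs from compound 2 in one place: hydrogen in place of methyl on an aromatic carbon. Read one bond further out, the change turns (4-methylbenzyl)amino into benzylamino, while the rest of the shared core is untouched. Among the measured compounds shown here, none of the measured compounds shows this change on its own, so nothing in the data shows its size. The loss of a single methyl on an aromatic carbon is expected to leave the number where it is, and a 1.2-fold higher number from compound 2 to compound 4 (0.07 log units; within the scatter) is estimated to be no step beyond the scatter. Compound 4 is therefore expected to give about 500 nM, within a range from 250 nM to 1000 nM.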

Compound 4, half-maximal inhibitory concentration: 1150 nM
Beside the measured number, compound 4's estimate is 2.3-fold (0.36 log units) below it; measured number above the stated range.
By their numbers in this assay, from the lowest: compounds 2 and 3 (each within the scatter of the next); then compound 4; then compound 1.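

In this assay the methyl on the aromatic carbon can now be read on its own: hydrogen in its place, turning 4-methylbenzyl into benzyl, gives (a 2.7-fold higher number from compound 2 to compound 4 (0.43 log units; beyond the scatter)), so this single carbon counts when 4-(dimethylamino)phenyl sits on the carbonyl carbon. The same compound opens a second site, since 4-(dimethylamino)phenyl in place of 3,5-dimethylphenyl on a carbonyl carbon gives (a 3.7-fold lower number from compound 1 to compound 4 (0.57 log units; beyond the scatter)), with the benzyl group the same on both sides, and both steps are modest. Nothing available says why either change moves the number.

The compounds shown carry only methyl and hydrogen at this place, so what an ethyl, a methoxy or a chlorine there would give stays open. Going by these compounds, whether the methyl counts the same with 3,5-dimethylphenyl on the carbonyl carbon also stays open.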